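This account rests on a few compounds, and the source may have more. Where it says the series, first, only, none or still open, it means among the compounds named here.

Compound 1 `COc1cc(-c2cc(C(=O)/C=C/c3ccc(Cl)cc3)nc3cc(-c4ccccc4)nn23)cc(OC)c1OC` gives 21600 nM in a functional assay on MDA-MB-231 cells (Homo sapiens) for antiproliferative activity, read by MTT assay, with a stated time of 24 h; a lower number here means a stronger inhibitor, a higher number a weaker inhibitor. Compound 2 `COc1ccc(-c2cc(C(=O)/C=C/c3ccc(Cl)cc3)nc3cc(-c4ccccc4)nn23)cc1OC` gives 23700 nM in this assay, the highest of the two numbers shown; the only measured step, a 1.1-fold higher number from compound 1 to compound 2 (0.04 log units; within the scatter), lies within the scatter. Compound 3 `COc1ccc(-c2cc(/C=C/C(=O)c3ccc(C)c(C)c3)nc3cc(-c4ccccc4)nn23)cc1OC` differs from compound 2 by 2-((3,4-dimethylphenyl)carbonyl)ethenyl in place of (2-(4-chlorophenyl)ethenyl)carbonyl on an aromatic carbon. No measured step bears on this change, since the single step shown concerns only a methoxy group elsewhere. The step of a 1.1-fold lower number from compound 2 to compound 3 (0.03 log units; within the scatter) is therefore expected to stay within the scatter in this assay, with no clear direction. Compound 3 is estimated at 22000 nM, range 7000 nM to 70000 nM, in this assay.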

Compound 3, half-maximal inhibitory concentration: 11500 nM
Compound 3: middle estimate off by 1.9-fold (0.28 log units), on the high side; low and high end bracket the measured number.
By their numbers in this assay, from the lowest: compounds 3, 1 and 2 (each within the scatter of the next, the first and the last beyond it).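

In this assay, going by these compounds alone, the side chain on the aromatic carbon next to the ring nitrogen proves to be a place where activity can move, with a 2.1-fold lower number from compound 2 to compound 3 (0.31 log units; beyond the scatter), whereas the only earlier step concerned a methoxy group elsewhere and stayed within the scatter. The step is modest and joins two differences: the carbonyl and ethenyl swap places in the chain, and 3,4-dimethylphenyl replaces 4-chlorophenyl. Nothing available explains this step.

Which of the two differences carries the step remains open, as does how this position responds to an amine or a carboxylic acid on the side-chain aromatic ring.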